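A Second Chloro on the Core: What to Expect

This account rests on a few compounds, and the source may have more. Where it says the series, first, only, none or still open, it means among the compounds named here.

Of the compounds shown here, two have so far been tested in a functional assay on LOX IMVI cells (Homo sapiens) for cytotoxicity, read by sulforhodamine B assay, with a stated time of 48 h; on this read-out lower numbers stand for stronger inhibition of growth and higher numbers for weaker inhibition of growth. Compound 1, `ClCc1cccc(Cn2cnc3c(Cl)nc(Cl)nc32)c1`, gives 1690 nM. Compound 2, `ClCc1ccccc1Cn1cnc2ncnc(Cl)c21`, gives 1340 nM. Compound 2 shows the lower of the two numbers, but its gap to compound 1 lies within the usual scatter of repeated measurements, so the two results cannot be told apart.

Compound 3, `ClCc1ccccc1Cn1cnc2nc(Cl)nc(Cl)c21`, has not yet been tested in this assay. It differs from compound 2 in one place: chloro in place of hydrogen on an aromatic carbon. Compound 1 already carries two chloro groups on the same core, together with a differently built benzyl group, and its result does not stand apart from that of compound 2. No direct comparison of this single change exists here, so the size of the step must be judged from these two results alone.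

The expected step in this assay is a 1.1-fold higher number from compound 2 to compound 3 (0.05 log units; within the scatter), meaning no change beyond the scatter in either direction. Compound 3 is therefore estimated at 1500 nM, within a range from 700 nM to 3200 nM.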

Compound 3, concentration for 50% growth inhibition: 160 nM
Compound 3: middle estimate off by 9.4-fold (0.97 log units), on the high side; the measured number lies below the stated range.
By their numbers in this assay, from the lowest: compound 3; then compounds 2 and 1 (each within the scatter of the next).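

In this assay, putting a chloro group on the aromatic carbon between two ring nitrogen atoms gives an 8.4-fold lower number from compound 2 to compound 3 (0.92 log units; beyond the scatter), so what this carbon carries matters for growth inhibition in these cells. Among these compounds, this is the first single change here that can be read, and it lies beyond the scatter, whereas the gap between the two earlier compounds could not be told apart from repeat-to-repeat variation. Compound 1 also has this second chloro group on its core, but it differs from compound 3 in more than one place, so the pair isolates no single change and the effect of the chloro group must rest on the step from compound 2 alone. No measurement available here explains why this one atom changes the result so much.

The compounds shown place only hydrogen or chloro on this carbon, so it remains open whether an amine, a methoxy group or a bromo group there would give a similar number. Going by these compounds, it also remains open whether the same step would appear with the benzyl group built as in compound 1.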